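The source may report more compounds than this note shows. Statements on the series, on what has been measured and on what is new or still open speak of the compounds shown alone.

Measured in an ADME assay on cells (Hepatocyte, Rattus norvegicus) for metabolic stability, using equilibrium dialysis; a lower number here means slower removal, a higher number faster removal of the compound: compound 1 `CC(=O)N[C@@H]1CCC[C@H](C(=O)Nc2cc(-c3cnn4c3COCC4)c(Cl)cn2)C1` gives 18 uL/min; compound 2 `CC(=O)N[C@@H]1CCC[C@H](C(=O)Nc2cc(-c3cnn4c3OCCC4)c(Cl)cn2)C1` gives 34 uL/min; compound 3 `CC(=O)N[C@@H]1CCC[C@H](C(=O)Nc2cc(-c3cnn4c3CC(C)C4)c(Cl)cn2)C1` gives 97 uL/min; 85 uL/min (2 entries).

Going by the values given here, compound 2 holds the highest of the two single numbers, with compound 1 nearest; the only measured step, a 1.9-fold higher number from compound 1 to compound 2 (0.28 log units; within the scatter), stays inside the scatter. Compound 4 `CC(=O)N[C@@H]1CCC[C@H](C(=O)Nc2cc(-c3cnc4n3CC(C)(C)C4)c(Cl)cn2)C1` differs from compound 2 in one place: a group of 10 heavy atoms (8 carbon, 2 nitrogen; one five-membered non-aromatic ring with 1 hetero atom, one five-membered aromatic ring with 2 hetero atoms) in place of a group of 9 heavy atoms (6 carbon, 2 nitrogen, 1 oxygen; one five-membered aromatic ring with 2 hetero atoms, one six-membered non-aromatic ring with 2 hetero atoms), on an aromatic carbon. Among the compounds with values here, no measured step covers this exact change. The repeated entries of compound 3, (the several entries of compound 3 in this assay, 97 uL/min; 85 uL/min (2 entries)), lie above the number for compound 2, so a move toward faster removal is expected for compound 4, a step of a 2.1-fold higher number from compound 2 to compound 4 (0.31 log units; beyond the scatter). In this assay compound 4 is therefore estimated at 70 uL/min, with a range of 30 uL/min to 160 uL/min.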

Compound 4, intrinsic clearance in a liver preparation (reported as CLH), per the amount of preparation that the assay uses: 28 uL/min
The estimate for compound 4 lay 2.5-fold (0.40 log units) above the measured number, and the stated range ends above it.
By their numbers in this assay, from the lowest: compounds 1, 4 and 2 (each within the scatter of the next).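

In this assay, exchanging the group on the aromatic carbon opposite the ring nitrogen for one with a five-membered non-aromatic ring and no oxygen gives a 1.2-fold lower number from compound 2 to compound 4 (0.08 log units; within the scatter), and the comparison with the other oxygen-bearing group gives a 1.6-fold higher number from compound 1 to compound 4 (0.19 log units; within the scatter). An oxygen-free group at this place can therefore sit level with both oxygen-bearing groups, which the entries of compound 3 alone had not shown: the several entries of compound 3 in this assay, 97 uL/min; 85 uL/min (2 entries)

As far as these compounds go, what separates compound 3 from compound 4 stays open, as does how a hydroxyl group or a fluorine on the five-membered non-aromatic ring would read in this assay.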